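A few compounds are considered here, and "the series" means these few. Any claim that something is new, unique, unknown or untested is made for them only; others in the source may bear on it.

Measured compounds:
compound 1 `COc1ccc(C2CC(=NO)CC(c3ccc(OC)cc3)N2C)cc1` — 380000 nM
compound 2 `COc1ccc(C2CC(=NOC(=O)c3ccc([N+](=O)[O-])cc3)CC(c3ccc(OC)cc3)N2C)cc1` — 280000 nM

Both compounds were tested in a functional assay, with a stated time of 30 min; on this read-out lower numbers stand for stronger inhibition and higher numbers for weaker inhibition. Compound 2 shows the lower of the two numbers, but its nearest neighbour, compound 1, lies within the usual scatter, so the two cannot be told apart. Among the compounds with values here, the only step available, a 1.4-fold lower number from compound 1 to compound 2 (0.13 log units; within the scatter), shows that placing a (4-nitrophenyl)carbonyl on the oxime oxygen changed nothing beyond the scatter.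

Compound 3 `COc1ccc(C2CC(=NOC(=O)c3cc(O)c(O)c(O)c3)CC(c3ccc(OC)cc3)N2C)cc1` has not yet been measured. It differs from compound 2 in one place: 3,4,5-trihydroxyphenyl in place of 4-nitrophenyl on a carbonyl carbon. Within the data shown here, no measured step bears directly on this exchange of one aryl ring for another on the carbonyl carbon. Among the measured compounds shown here, the one step that exists shows the region around the oxime oxygen tolerating a large addition without effect, so the expectation for compound 3 in this assay is a step of a 1.1-fold higher number from compound 2 to compound 3 (0.03 log units; within the scatter), not beyond the scatter. Compound 3 is therefore estimated at 300000 nM, with a range from 100000 nM to 900000 nM.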

Compound 3, half-maximal inhibitory concentration: 18000 nM
Beside the measured number, compound 3's estimate is 17-fold (1.22 log units) above it; the whole stated range lies above it.
By their numbers in this assay, from the lowest: compound 3; then compounds 2 and 1 (each within the scatter of the next).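

In this assay the aryl group on the carbonyl carbon clearly matters: 3,4,5-trihydroxyphenyl in place of 4-nitrophenyl gives a 16-fold lower number from compound 2 to compound 3 (1.19 log units; beyond the scatter) even though the two groups have equal heavy-atom counts, so group size alone does not set the result here. The earlier pair showed no change beyond the scatter on adding (4-nitrophenyl)carbonyl to the oxygen, whereas (3,4,5-trihydroxyphenyl)carbonyl in place of hydrogen on that oxygen gives a 21-fold lower number from compound 1 to compound 3 (1.32 log units; beyond the scatter) and stands apart from both other compounds. The data offer no measurement that explains this gain.

As far as these compounds go, it remains open whether all three hydroxyl groups are needed, or whether one would do. A phenyl ring carrying methoxy groups in their place, or an amine or a carboxylic acid on the ring, would help to show which feature of the new group counts.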